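The source may report more compounds than this note shows. Statements on the series, on what has been measured and on what is new or still open speak of the compounds shown alone.

Compound 1 `CCCCCC[S+]([O-])c1cc(-c2ccccc2)c(-c2ccccc2)nn1` and compound 2 `CCCCCCC[S+]([O-])c1cc(-c2ccccc2)c(-c2ccccc2)nn1` share a core bearing an alkyl chain on a sulfur. In an assay on microsomes from liver for inhibition of sterol O-acyltransferase 1 (Rattus norvegicus) (on this read-out lower numbers stand for stronger inhibition and higher numbers for weaker inhibition), compound 1 gives 75000 nM, and compound 2 gives 77000 nM. The change between them, (methyl in place of hydrogen on a saturated chain carbon, six bonds along the chain from a sulfur), yields a 1.0-fold higher number from compound 1 to compound 2 (0.01 log units; within the scatter). Compound 3 `CCCCCCCCS(=O)(=O)c1cc(-c2ccccc2)c(-c2ccccc2)nn1` carries its chain on a sulfonyl sulfur; the difference between the core of compound 1 and that of compound 3 is not broken down here. In this assay compound 3 gives 36000 nM, the lowest of the three numbers. Compound 4 `CCCCCCCCCS(=O)(=O)c1cc(-c2ccccc2)c(-c2ccccc2)nn1` is not yet measured; it differs from compound 3 by methyl in place of hydrogen on a saturated chain carbon, eight bonds along the chain from a sulfonyl sulfur. This is the same kind of change as that from compound 1 to compound 2, though the place differs: six bonds along the chain from a sulfur there, eight bonds along the chain from a sulfonyl sulfur here. Because a 1.0-fold higher number from compound 1 to compound 2 (0.01 log units; within the scatter) lay within the scatter, a similarly small step is expected, a 1.1-fold lower number from compound 3 to compound 4 (0.02 log units; within the scatter). Compound 4 is estimated at 34000 nM, with an expected range from 15000 nM to 80000 nM.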

Compound 4, half-maximal inhibitory concentration: 76000 nM
Beside the measured number, compound 4's estimate is 2.2-fold (0.35 log units) below it, within the range that was stated.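

On the core of compound 3, the change gives a 2.1-fold higher number from compound 3 to compound 4 (0.32 log units; beyond the scatter) in this assay. Set beside the earlier step, this does not separate the two cores: the same change on two cores in this assay, a 1.0-fold higher number (0.01 log units; within the scatter) from compound 1 to compound 2 and a 2.1-fold higher number (0.32 log units; beyond the scatter) from compound 3 to compound 4, 2.1-fold (0.31 log units) apart, within the scatter of two such steps

The data therefore show no measurable difference in how the change carries from one core to the other, but a single pair on each core, with the change at a different place along the chain, does not show that it transfers generally or that the two steps are equal. The compounds shown leave open whether the core or the place along the chain sets the size of the step. They also leave open what a longer chain, an amine or a carboxylic acid in place of the methyl would give on either core.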